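Replacing the Ether Side Chain of Compound 1 with Butyl

The source may report more compounds than this note shows. Statements on the series, on what has been measured and on what is new or still open speak of the compounds shown alone.

Measured in an assay on cells with melanin-concentrating hormone receptor 1 (Homo sapiens) as the target, read by radioligand binding; on this read-out lower numbers stand for stronger inhibition and higher numbers for weaker inhibition:
Compound 1 `CCOCC(C)Oc1cccc2ccc(N)nc12` gives 1070 nM.
Compound 2 `CC(CC(C)(C)C)Oc1cccc2ccc(N3CCCC3)nc12` gives > 2000 nM, a limit of the assay.
Compound 3 `CC(CC(C)(C)C)Oc1cccc2ccc(N3CCCCC3)nc12` gives > 2000 nM, also a limit.

For the measured compounds named here, compound 1 holds the only number in this assay; the two other values are limits. The step that the two limits leave unreadable from compound 2 to compound 3 is therefore unreadable, as the limit of > 2000 nM in this assay, at which 2 of the 3 values shown sit, shows. Compound 4 `CCCCOc1cccc2ccc(N)nc12` differs from compound 1 by a group of 4 heavy atoms (4 carbon; no ring) in place of a group of 6 heavy atoms (5 carbon, 1 oxygen; no ring), on an oxygen on an aromatic ring. Going by the values given here, no measured step bears on this change, since compounds 2 and 3 differ from compound 1 in more than one place. With nothing to point to, a step of a 1.1-fold lower number from compound 1 to compound 4 (0.03 log units; within the scatter) is expected, none beyond the scatter. Compound 4 is thus estimated at 1000 nM, between 400 nM and 2500 nM.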

Compound 4, half-maximal inhibitory concentration: 789 nM
Beside the measured number, compound 4's estimate is 1.3-fold (0.10 log units) above it; the measured number falls inside the stated range.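

Here a 1.4-fold lower number from compound 1 to compound 4 (0.13 log units; within the scatter) is the first readable step on this oxygen in this assay and it lies within the scatter. Butyl, with no hydrogen-bond acceptor, stands in for a group holding one, and the two compounds cannot be told apart on this read-out. Nothing shown gives a cause for this step.

Open, as far as these compounds go, is whether an amine or a carboxylic acid at the end of the chain on this oxygen would move the number beyond the scatter. Also open, from the compounds shown here alone, is how a phenyl ring in place of butyl would read.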